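Piperidine in place of hydroxyl on a 5-HT4 agonist chain

The compounds below may be only part of what the source reports. "The series", "measured", "known", "first", "only" and "open" are said of these compounds alone.

Of the compounds shown here, two sharing a core have been measured so far. In a functional assay on HEK293 cells for agonist activity at 5-hydroxytryptamine receptor 4 (Homo sapiens), read by cAMP accumulation (on this read-out lower numbers stand for an effect already at smaller amounts and higher numbers for an effect only at larger amounts of compound), compound 1 `COc1cc(N)c(Cl)cc1C(=O)NCC1CCNCC1` gives 398 nM, while compound 2 `COc1cc(N)c(Cl)cc1C(=O)NC1CCN(CCCCCO)CC1` gives 15.9 nM, the lowest of the two numbers and a gap beyond the scatter from compound 1. Compound 3 `COc1cc(N)c(Cl)cc1C(=O)NC1CCN(CCCCCN2CCCCC2)CC1` is not yet measured in this assay. It differs from compound 2 by a single change: piperidin-1-yl in place of hydroxy on a saturated chain carbon, five bonds along the chain from an amine nitrogen in a ring. Going by the values given here, no measured pair shows exactly this change, so there is no step from which to read its size. The account therefore rests on compound 2 alone, whose value of 15.9 nM is the natural anchor. Compound 3 is expected to stay close to that anchor, with a step from a 1.6-fold lower number from compound 2 to compound 3 (0.20 log units; within the scatter) that could fall in either direction but is not expected to go far beyond the scatter. Compound 3 is estimated at 10 nM, within a range from 3 nM to 40 nM.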

Compound 3, half-maximal effective concentration: 5.01 nM
Estimate against measurement, compound 3: 2.0-fold (0.30 log units) above; the measured number falls inside the stated range.
By their numbers in this assay, from the lowest: compound 3; then compound 2; then compound 1.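

In this assay, piperidin-1-yl in place of hydroxy on a saturated chain carbon, five bonds along the chain from an amine nitrogen in a ring, gives a 3.2-fold lower number from compound 2 to compound 3 (0.50 log units; beyond the scatter) and so moves the number down rather than up. The change removes a hydrogen-bond donor and brings in 6 heavy atoms for 1, which shows that neither the hydroxy group nor its donor is needed at this place for a low number in this read-out. Nothing measured here says why the number falls. 

The compounds shown leave open whether the step belongs to the nitrogen or to the ring, which an open-chain diethylamino group or a morpholine at the same place could separate. They also leave open how a carboxylic acid at the chain end, or a shorter or longer chain carrying the piperidine, would read.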